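Isopropyl on the ring amide nitrogen of compound 1

A few compounds are considered here, and "the series" means these few. Any claim that something is new, unique, unknown or untested is made for them only; others in the source may bear on it.

Compound 1 `COc1ncc(-c2ccc3c(c2)NC(=O)CO3)cc1NS(=O)(=O)c1ccc(F)cc1` — in a functional assay on HeLa cells (Homo sapiens) for antiproliferative activity, read by MTT assay, with a stated time of 72 h (a higher number here means a weaker inhibitor, a lower number a stronger inhibitor), compound 1 gives 7110 nM.
Compound 2 `O=C1COc2ccc(-c3cnc(Cl)c(NS(=O)(=O)c4ccc(F)cc4)c3)cc2N1` — in this assay compound 2 gives 15600 nM.
Compound 3 `O=C1COc2ccc(-c3cnc4ccccc4c3)cc2N1` — in this assay compound 3 reaches only the limit > 40000 nM.

Compound 1 holds the lowest of the two numbers. Among the measured compounds shown here, the only one-place step among the measured compounds is a 2.2-fold higher number from compound 1 to compound 2 (0.34 log units; beyond the scatter). Compound 3 sits at the limit of > 40000 nM in this assay, at which 1 of the 3 values shown sits, a limit and not a number.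

Compound 4 `COc1ncc(-c2ccc3c(c2)N(C(C)C)C(=O)CO3)cc1NS(=O)(=O)c1ccc(F)cc1` differs from compound 1 by isopropyl in place of hydrogen on an amide-type nitrogen in a ring. For the measured compounds named here, no measured step touches the ring amide nitrogen; the chloro-for-methoxy step concerns another part of the shared core and gives no guide to size or direction here. The expectation for compound 4 is therefore set near compound 1 with a wide range: the estimate is 12000 nM, from 3500 nM to 45000 nM. That estimate corresponds to an expected step of a 1.7-fold higher number from compound 1 to compound 4 (0.23 log units; within the scatter).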

Compound 4, half-maximal inhibitory concentration: 2790 nM
For compound 4 the middle estimate is 4.3-fold (0.63 log units) above the measured one; measured number below the stated range.
By their numbers in this assay, from the lowest: compound 4; then compound 1; then compound 2. At a limit, above all of these: compound 3.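

In this assay, among the compounds shown here, isopropyl in place of the amide hydrogen gives a 2.5-fold lower number from compound 1 to compound 4 (0.41 log units; beyond the scatter), the first reading at this nitrogen. The amide hydrogen of compound 1 is therefore not required for activity here, and this position accepts a branched alkyl group with a modest gain. Nothing measured here gives a reason for the gain.

One substituent cannot show a trend at this nitrogen: methyl, a longer chain such as n-butyl, or a chain ending in an amine could go either way. Going by these compounds, whether isopropyl gives a similar step on compound 2 also remains open.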